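A few compounds are considered here, and "the series" means these few. Any claim that something is new, unique, unknown or untested is made for them only; others in the source may bear on it.

Measured in a functional assay on HT-29 cells (Homo sapiens) for cytotoxicity, read by sulforhodamine B assay; a higher number here means that more compound is tolerated, a lower number that less compound is tolerated:
- Compound 1 `O=c1oc2ccc(Cl)cc2cc1-c1cn2nc(-c3c([O-])[o+]nn3-c3ccc(Cl)cc3)sc2n1`: > 80 ug/mL, a limit
- Compound 2 `O=c1oc2ccccc2cc1-c1cn2nc(-c3c([O-])[o+]nn3-c3ccccc3)sc2n1`: > 70 ug/mL, a limit

Compound 1 stands at a limit of this assay, > 80 ug/mL, and has no exact number. Compound 2 also has only a limit, > 70 ug/mL. Compound 3 `O=c1oc2ccc(Cl)cc2cc1-c1cn2nc(-c3c([O-])[o+]nn3-c3ccccc3)sc2n1` differs from compound 1 by hydrogen in place of chloro on an aromatic carbon, para to a large group, taking 4-chlorophenyl to phenyl (hydrogen in place of chloro on an aromatic carbon). Among the measured compounds shown here, no measured step shows what this change does in this assay, so none beyond the scatter is expected. The expected step of an at least 1.0-fold lower number from compound 1 to compound 3 (0.02 log units; that floor lies within the scatter) is therefore small. Compound 3 is estimated at 75 ug/mL, with an expected range of 40 ug/mL to 120 ug/mL.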

Compound 3, concentration lethal to 50% of the cells: > 80 ug/mL
Compound 3 ended at the assay's limit (the forecaster's own chance of this, stated with the estimate: 75%); at least 1.0-fold (0.02 log units) between middle value and limit.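

In this assay, among the compounds shown here, compound 3 gives > 80 ug/mL, a limit, and no step linking it to compound 1 or compound 2 can be read. Where the lethal concentration of any of the three lies, and what hydrogen in place of chloro does to it, stays open.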